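Methyl Added to the Phenylsulfonyl Group

The source may report more compounds than this note shows. Statements on the series, on what has been measured and on what is new or still open speak of the compounds shown alone.

In an assay on HEK293 cells for displacement of a labelled ligand from 5-hydroxytryptamine receptor 6 (Homo sapiens) (a higher number here means a weaker inhibitor, a lower number a stronger inhibitor), compound 2 `O=S(=O)(c1ccccc1)n1ccc2ccc(N3CCN4CCCCC4C3)cc21` gives 5.7 nM, with only compound 1 `O=S(=O)(c1ccc2ccccc2c1)n1ccc2ccc(N3CCN4CCCCC4C3)cc21` beside it, which gives 3 nM; the step of a 1.9-fold higher number from compound 1 to compound 2 (0.28 log units; within the scatter) stays within the scatter, so the two stand together. Compound 3 `Cc1ccc(S(=O)(=O)n2ccc3ccc(N4CCN5CCCCC5C4)cc32)cc1` differs from compound 2 by methyl in place of hydrogen on an aromatic carbon. Among the compounds with values here, no measured step adds a methyl; the single comparison available, the exchange of aryl group between compound 1 and compound 2, hardly moved the number. Compound 3 is therefore expected to give about 5 nM, between 2 nM and 15 nM, a step of a 1.1-fold lower number from compound 2 to compound 3 (0.06 log units; within the scatter) not expected to exceed the scatter.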

Compound 3, inhibition constant: 4.9 nM
Estimate against measurement, compound 3: 1.0-fold (0.01 log units) above, and the stated range covers the measured number.
By their numbers in this assay, from the lowest: compounds 1, 3 and 2 (each within the scatter of the next).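

In this assay, methyl in place of hydrogen on this aromatic carbon, para to a large group, gives a 1.2-fold lower number from compound 2 to compound 3 (0.07 log units; within the scatter), so this carbon carries a methyl and the number stays within the scatter. The exchange of naphthalen-2-yl for 4-methylphenyl on the sulfonyl sulfur gives a 1.6-fold higher number from compound 1 to compound 3 (0.21 log units; within the scatter), so compounds 1, 2 and 3 stand together. Nothing measured here accounts for this result. On these data alone, whether an amine, a carboxylic acid or a longer chain on this same carbon would hold the number as methyl does remains open.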